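A few compounds are considered here, and "the series" means these few. Any claim that something is new, unique, unknown or untested is made for them only; others in the source may bear on it.

In a functional assay on the whole organism for agonist activity, with Mus musculus as the target (a lower number here means that less compound is needed, a higher number that more compound is needed for the effect), compound 2 `CC(=O)NCC#CCn1ccnc1` stands at > 100 mg/kg, which is a limit of the assay and not a number. Compound 3 `CC(=O)N(C)CC#CCn1ccnc1` differs from it by one change, methyl in place of hydrogen on an amide-type nitrogen. Compound 1 `CC(=O)N(C)C(C)C#CCn1ccnc1` also carries a methyl on that nitrogen, differs elsewhere as well, and gives 3 mg/kg in this assay. On that single comparison, a large drop in the dose needed is expected, an at least 5.0-fold lower number from compound 2 to compound 3 (0.69 log units; beyond the scatter). For compound 3 the estimated dose is 20 mg/kg, with an expected range from 4 mg/kg to 100 mg/kg.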

Compound 3, dose for half-maximal effect: 1.4 mg/kg
Compound 3: the middle estimate sits 14-fold (1.15 log units) above what was measured, outside the stated range (below it).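

In this assay, methyl in place of hydrogen on the amide-type nitrogen gives an at least 71-fold lower number from compound 2 to compound 3 (1.85 log units; beyond the scatter), so this one change alone separates the two compounds. Compound 2 stands at a limit of the assay, not a number: the limit of > 100 mg/kg in this assay, at which 1 of the 3 values shown sits. The methyl on the saturated chain carbon bound to an amide-type nitrogen and a triple-bonded carbon matters far less, since hydrogen in its place gives only a modest 2.1-fold lower number from compound 1 to compound 3 (0.33 log units; beyond the scatter).

On these data alone, whether an ethyl group or a longer chain on the amide-type nitrogen would serve as well as methyl stays open. So does the effect of an ethyl group on that saturated chain carbon.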